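The compounds below may be only part of what the source reports. "The series", "measured", "known", "first", "only" and "open" are said of these compounds alone.

Compound 2, with the structure `C=C(Br)C(=O)Nc1cccc(-c2cn3nc(-c4ccccc4)sc3n2)c1`, gives 960 nM in a functional assay on CCRF-CEM cells (Homo sapiens) for inhibition, read by cell counting, with a stated time of 3 days (a higher number here means a weaker inhibitor, a lower number a stronger inhibitor), and holds the lowest number of the three compounds measured there. Compound 1, with the structure `CCc1ccc(-c2nn3cc(-c4cccc(N)c4)nc3s2)cc1`, gives 22000 nM in this assay, and compound 3, with the structure `Nc1cccc(-c2cn3nc(-c4ccccc4)sc3n2)c1`, gives 33000 nM. The step from compound 2 to compound 3 was a 34-fold higher number from compound 2 to compound 3 (1.54 log units; beyond the scatter), while the step from compound 1 to compound 3 was a 1.5-fold higher number from compound 1 to compound 3 (0.18 log units; within the scatter).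

Compound 4, with the structure `C=C(Br)C(=O)Nc1cccc(-c2cn3nc(-c4ccc(OC)cc4)sc3n2)c1`, differs from compound 2 in one place: methoxy in place of hydrogen on an aromatic carbon. For the measured compounds named here, no measured pair carries a methoxy, so the only step that bears on a change at this ring is the one from compound 1 to compound 3, where ethyl in place of hydrogen on an aromatic carbon of this ring stayed within the scatter. The step that changed the number greatly, from compound 2 to compound 3, concerned the (1-bromoethenyl)carbonyl, which compound 4 keeps. A step of no more than the scatter is therefore expected, a 1.0-fold higher number from compound 2 to compound 4 (0.02 log units; within the scatter). Compound 4 is estimated to give 1000 nM in this assay, within a range from 400 nM to 2500 nM.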

Compound 4, half-maximal inhibitory concentration: 1200 nM
Beside the measured number, compound 4's estimate is 1.2-fold (0.08 log units) below it; measured number inside the range.
By their numbers in this assay, from the lowest: compounds 2 and 4 (each within the scatter of the next); then compounds 1 and 3 (each within the scatter of the next).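

In this assay the change from phenyl to 4-methoxyphenyl, on an aromatic carbon para to a large group, gives a 1.3-fold higher number from compound 2 to compound 4 (0.10 log units; within the scatter) and so stays within the scatter. The earlier step at this ring, a 1.5-fold higher number from compound 1 to compound 3 (0.18 log units; within the scatter), was read only among compounds without the (1-bromoethenyl)carbonyl, whose numbers are high; this step shows that a substituent at this ring is also accommodated when that group is present and the numbers are low. Nothing measured here explains why the number holds at this position.

The compounds shown leave open whether an amine, a carboxylic acid or a longer chain at this place would stay as close to compound 2 . They also leave open how a methoxy would behave on a compound with the free amine in place of the (1-bromoethenyl)carbonyl.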